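The source may hold more compounds than are shown below. What is called first, only, known or untested is meant among the compounds shown, and "the series" means these compounds.

Working notes on the series. Compound 1 `Fc1cc(Cl)ccc1-c1ccc(Cn2nnc3c(C(F)(F)F)cccc32)cn1` gives 0.04 mL/min/g in an ADME assay on microsomes from liver (Homo sapiens) for metabolic stability, tested at 2.5 uM; a higher number here means faster removal of the compound, a lower number slower removal. Compound 2 `Fc1cc(Cl)ccc1-c1ccc(Cn2nnc3c(Br)cccc32)cn1` gives 0.1 mL/min/g in this assay; the change from compound 1 to compound 2 is bromo in place of trifluoromethyl on an aromatic carbon and the step is a 2.5-fold higher number from compound 1 to compound 2 (0.40 log units; beyond the scatter). Compound 3 `FC(F)(F)c1cc(Br)c2nnn(CC3CC3)c2c1` gives 0.1 mL/min/g in this assay, level with compound 2 at the digits shown and within the scatter of it; the difference between the core of compound 3 and the core of compound 1 is not broken down here.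

Compound 4 `Brc1cc(Br)c2nnn(CC3CC3)c2c1` is not yet measured in this assay. From compound 3 to compound 4 the change is bromo in place of trifluoromethyl on an aromatic carbon. This is the same kind of change as from compound 1 to compound 2, not the same: there the position was ortho to a fused ring and meta to a fused ring, here it is meta to a bromo group, meta to a fused ring and para to a fused ring, on a different core. The step from compound 3 to compound 4 is expected to be a 2.2-fold higher number from compound 3 to compound 4 (0.34 log units; beyond the scatter), set beside a 2.5-fold higher number from compound 1 to compound 2 (0.40 log units; beyond the scatter) and resting on it. Compound 4 is therefore estimated at 0.22 mL/min/g, with 0.08 mL/min/g to 0.55 mL/min/g as the range.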

Compound 4, intrinsic clearance in a liver preparation (reported as CLH), per the amount of preparation that the assay uses: 0.6 mL/min/g
Estimate against measurement, compound 4: 2.7-fold (0.44 log units) below; the whole stated range lies below it.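

Bromo in place of trifluoromethyl on an aromatic carbon raises the number in this assay on both cores, with a 6.0-fold higher number from compound 3 to compound 4 (0.78 log units; beyond the scatter) set against the earlier 2.5-fold higher number from compound 1 to compound 2 (0.40 log units; beyond the scatter). The direction carries over in these two pairs, and the sizes cannot be told apart: the same change on two cores in this assay, a 2.5-fold higher number (0.40 log units; beyond the scatter) from compound 1 to compound 2 and a 6.0-fold higher number (0.78 log units; beyond the scatter) from compound 3 to compound 4, 2.4-fold (0.38 log units) apart, within the scatter of two such steps. Going by these compounds alone, this does not show a rule for other cores, and with only two pairs, whose aromatic carbons also have different surroundings, it does not separate any effect of the core from one of the place on the ring.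

Still open, from the compounds shown here alone, is how a nitrile or an amine on that aromatic carbon would compare with bromo and trifluoromethyl in this assay. Going by these compounds, it is also open whether the same change keeps its direction on a third core, for instance one carrying a carboxylic acid.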